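Series notes: aryl swap on the ring nitrogen, compound 4

The compounds below may be only part of what the source reports. "The series", "measured", "known", "first", "only" and "open" are said of these compounds alone.

Measured so far in a functional assay on MCF7 cells (Homo sapiens) for cytotoxicity, read by MTT assay, with a stated time of 72 h; on this read-out lower numbers stand for stronger inhibition and higher numbers for weaker inhibition:
- compound 1 `Cc1cc(=O)n(-c2ccccc2C(F)(F)F)nc1C(=O)Nc1ccc(Oc2ncnc3c2ccn3C)cc1` gives 7840 nM.
- compound 2 `Cc1cc(=O)n(-c2ccc(Br)cc2F)nc1C(=O)Nc1ccc(Oc2ncnc3c2ccn3C)c(F)c1` gives > 60000 nM, which is a limit of the assay.
- compound 3 `Cc1cc(=O)n(-c2cccc(F)c2)nc1C(=O)Nc1ccc(Oc2ncnc3c2ccn3C)c(F)c1` gives > 60000 nM, also a limit of the assay.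
- compound 4 `Cc1cc(=O)n(-c2ccccc2C(F)(F)F)nc1C(=O)Nc1ccc(Oc2ncnc3c2ccn3C)c(F)c1` is not yet measured.

Compound 3 therefore stands only at a limit; of the three values shown, two sit at that limit (the limit of > 60000 nM in this assay, at which 2 of the 3 values shown sit), and only compound 1 gives a number. Going by the values given here, the single step with a shared partner, a step that the two limits leave unreadable from compound 2 to compound 3, runs between two limits and its size cannot be read.

The change to compound 4 is 2-(trifluoromethyl)phenyl in place of 3-fluorophenyl on an aromatic nitrogen. The one measured compound carrying the same 2-(trifluoromethyl)phenyl group is compound 1, which in this assay gives a number rather than a limit, though compound 1 also lacks the fluorine on the anilide ring that compound 3 and compound 4 share, so no listed step isolates the aryl swap alone.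

Expected: compound 4 is estimated to move back into the measurable range, with an at least 3.0-fold lower number from compound 3 to compound 4 (0.47 log units; beyond the scatter), though the step cannot be sized from a limit; the estimate for compound 4 is 20000 nM, between 5000 nM and 60000 nM, with a real chance that only a limit is reported.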

Compound 4, half-maximal inhibitory concentration: > 60000 nM
Compound 4 ended at the assay's limit; the forecaster's own chance of this, stated with the estimate: 35%; middle value at least 3.0-fold (0.47 log units) away from the limit.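

Compound 4 stands at a limit of the assay and gives no number in this assay, so carrying 2-(trifluoromethyl)phenyl on the aromatic nitrogen does not by itself keep a compound in the readable range. Going by these compounds alone, the one step that can be read holds that group fixed and changes the anilide ring, with fluoro in place of hydrogen on an aromatic carbon: an at least 7.6-fold higher number from compound 1 to compound 4 (0.88 log units; beyond the scatter), and this is the first pair that isolates this change. The steps among compound 2, compound 3 and compound 4 run between limits and cannot be read, which leaves these three aryl groups unranked, and every compound shown with the anilide fluorine now sits at the same limit: the limit of > 60000 nM in this assay, at which 3 of the 4 values shown sit.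

Compound 1 is the only compound shown without that fluorine, which leaves open whether the same step would appear with other aryl groups on the ring nitrogen. Also open, going by these compounds, is whether a methoxy or chloro group in place of the anilide fluorine, or an amine or carboxylic acid on the aryl group, would give a number in this assay.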